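The compounds below may be only part of what the source reports. "The series", "measured", "known", "first", "only" and "open" are said of these compounds alone.

Measured so far:
compound 1, `O=[N+]([O-])c1ccc(-c2nn(-c3ccccc3)cc2-c2nnc(-c3ccccc3)o2)cc1`: 74.3 mg/kg
compound 2, `Fc1ccc(-c2nn(-c3ccccc3)cc2-c2nnc(-c3ccc(Cl)cc3)o2)cc1`: 183 mg/kg

Both numbers come from a functional assay on the whole organism for inhibition, with Rattus norvegicus as the target, read by paw edema, with stated times of 1 h and 2 h; on this read-out higher numbers stand for an effect only at larger amounts of compound and lower numbers for an effect already at smaller amounts. Compound 1 gives the lower of the two numbers, and compound 2 sits higher by a gap beyond the usual scatter. Compound 3, `O=[N+]([O-])c1ccc(-c2nn(-c3ccccc3)cc2-c2nnc(-c3ccc(Cl)cc3)o2)cc1`, has not yet been measured in this assay. It differs from compound 1 in one place: chloro in place of hydrogen on an aromatic carbon. Among the measured compounds shown here, compound 2 carries the same chloro group on that ring, but it also differs from compound 1 elsewhere, so no single-change step is available for comparison. The step from compound 1 to compound 3 is therefore expected to be modest, a small rise in the number or nothing beyond the scatter, and the expected step is a 1.2-fold higher number from compound 1 to compound 3 (0.08 log units; within the scatter). Compound 3 is expected to give about 90 mg/kg in this assay, with a range from 40 mg/kg to 200 mg/kg.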

Compound 3, dose for half-maximal effect: 167 mg/kg
The estimate for compound 3 lay 1.9-fold (0.27 log units) below the measured number; the range from low to high includes it.
By their numbers in this assay, from the lowest: compound 1; then compounds 3 and 2 (each within the scatter of the next).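

In this assay, the change from phenyl to 4-chlorophenyl gives a 2.2-fold higher number from compound 1 to compound 3 (0.35 log units; beyond the scatter), so this position, on a ring that carries only a hydrogen in compound 1, responds to a single added chloro group. The second step, nitro in place of fluoro on an aromatic carbon, gives a 1.1-fold lower number from compound 2 to compound 3 (0.04 log units; within the scatter), so with the chloro group present, this swap produces no change that can be told apart from the usual scatter. Nothing measured here explains either step.

Among the compounds shown here, whether chloro has the same effect when fluoro stands in place of nitro remains open, as only one such pair can be read. Also open, on these data alone, is how a methoxy group, an amine or a carboxylic acid would compare with chloro at this position.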